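The source may report more compounds than this note shows. Statements on the series, on what has been measured and on what is new or still open speak of the compounds shown alone.

In an ADME assay on THP-1 cells (Homo sapiens) for cytotoxicity (on this read-out lower numbers stand for higher toxicity in this test and higher numbers for lower toxicity in this test), compound 1 `c1ccc(Nc2c(-c3ccccn3)nc3ccccn23)cc1` gives 6690 nM. Compound 2 `Cc1ccn2c(NC3CCCC3)c(-c3ccc(N(C)C)cc3)nc2c1` reaches only a limit of this assay, > 50000 nM. Compound 3 `COc1ccc(-c2nc3cc(C)ccn3c2NC2CCCC2)cc1` likewise stops at a limit of this assay, > 50000 nM. The step from compound 2 to compound 3 in this assay, a step that the two limits leave unreadable from compound 2 to compound 3, cannot be read, since both values sit at the limit of > 50000 nM in this assay, at which 2 of the 3 values shown sit. Compound 4 `COc1ccc(-c2nc3cc(C)ccn3c2NC2CCCCC2)cc1` differs from compound 3 by cyclohexyl in place of cyclopentyl on a nitrogen on an aromatic ring. No measured pair among these compounds carries this change, and the one measured step is itself unreadable, so nothing shown gives a direction or size for it. Compound 4 is therefore expected to stay at the limit of this assay, with a number no higher from compound 3 to compound 4 (the limit leaves the size open) expected to be no step beyond the scatter. The estimate for compound 4 in this assay is 50000 nM, between 20000 nM and 120000 nM.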

Compound 4, half-maximal cytotoxic concentration: > 50000 nM
Compound 4: a limit, no number; the forecaster's own chance of this, stated with the estimate: 75%; the middle value sits exactly at the limit.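

Compound 3 and compound 4 both stop at a limit in this assay, so no step can be read between them: the limit of > 50000 nM in this assay, at which 3 of the 4 values shown sit.

The compounds shown leave open whether cyclohexyl in place of cyclopentyl changes the read-out at all.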